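Swapping trifluoromethylphenyl for dimethoxyphenyl on compound 2

This account rests on a few compounds, and the source may have more. Where it says the series, first, only, none or still open, it means among the compounds named here.

Of the compounds shown here, two sharing the same aryl ether tail have been measured in a functional assay on HT-29 cells (Homo sapiens) for cytotoxicity, read by MTT assay, with a stated time of 72 h; a lower number here means a stronger inhibitor, a higher number a weaker inhibitor. Compound 1 `Fc1ccc(Nc2cc(Nc3ccc(Oc4ccncc4-c4cccnc4)c(F)c3)ncn2)cc1F` gives 2320 nM in this assay. Compound 2 `Cn1c(=O)c(C(=O)Nc2ccc(Oc3ccncc3-c3cccnc3)c(F)c2)nn(-c2cccc(C(F)(F)F)c2)c1=O` gives 510 nM in this assay, the lowest of the two numbers and the stronger inhibitor, since its gap to compound 1 lies beyond the usual scatter. Among the compounds with values here, no pair of measured compounds differing in only one place is available, so nothing yet shows how single changes on the core of compound 2 shift the number.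

Compound 3 `COc1ccc(-n2nc(C(=O)Nc3ccc(Oc4ccncc4-c4cccnc4)c(F)c3)c(=O)n(C)c2=O)c(OC)c1` is the next compound to be measured in this assay. It differs from compound 2 only in one place: 2,4-dimethoxyphenyl in place of 3-(trifluoromethyl)phenyl on an aromatic nitrogen. Within the data shown here, with no comparable step among the measured compounds, the direction of the change cannot be read from the data; a modest shift in either direction, possibly within the scatter, seems the most reasonable expectation. The expected step is a 1.8-fold higher number from compound 2 to compound 3 (0.25 log units; within the scatter), a slight weakening. Compound 3 is therefore estimated to give 900 nM in this assay, with a likely range from 250 nM to 3500 nM.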

Compound 3, half-maximal inhibitory concentration: 890 nM
For compound 3 the middle estimate is 1.0-fold (0.00 log units) above the measured one, within the range that was stated.
By their numbers in this assay, from the lowest: compounds 2 and 3 (each within the scatter of the next); then compound 1.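

In this assay, within the data shown here, this is the first comparison between two compounds that differ in only one place, and replacing 3-(trifluoromethyl)phenyl with 2,4-dimethoxyphenyl on the aromatic nitrogen gives a 1.7-fold higher number from compound 2 to compound 3 (0.24 log units; within the scatter). At this position, therefore, an aromatic ring carrying fluorine atoms can give way to one carrying oxygen atoms, with hydrogen-bond acceptors added to the group, and the number stays within the usual scatter of repeated measurements. Nothing shown here offers a measured reason for this outcome.

Among these compounds, a single pair shows only that these two groups give values within the scatter of each other, so it cannot tell whether the same holds for other groups at this position, such as a plain phenyl ring, a phenyl ring carrying an amine or a carboxylic acid, or a simple alkyl chain with no ring at all. It also leaves open how each methoxy group contributes on its own, since the two enter together and a phenyl ring with just one of them would be needed to separate them.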